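A Propargylamino Compound at the Limit, and an Allyl Neighbour

This account rests on a few compounds, and the source may have more. Where it says the series, first, only, none or still open, it means among the compounds named here.

In an ADME assay on CCRF-CEM cells (Homo sapiens) for cytotoxicity, with a stated time of 5 days (on this read-out higher numbers stand for weaker inhibition and lower numbers for stronger inhibition), compound 1 `[N-]=[N+]=N[C@H]1C[C@H](n2cnc3c(NC4CC4)nc(N)nc32)O[C@@H]1CO` gives > 100000 nM, which is a limit of the assay and not a number. Compound 2 `C#CCNc1nc(N)nc2c1ncn2[C@H]1C[C@H](N=[N+]=[N-])[C@@H](CO)O1` gives > 100000 nM, and this too is only a limit. For the measured compounds named here, compound 2 therefore has no readable position, and the one other value beside it is also a limit.

Compound 3 `C=CCN(C)c1nc(N)nc2c1ncn2[C@H]1C[C@H](N=[N+]=[N-])[C@@H](CO)O1` keeps the shared core and carries allyl(methyl)amino in place of propargylamino on an aromatic carbon. Going by the values given here, the one measured step that bears on this change is a step that the two limits leave unreadable from compound 1 to compound 2, with propargyl in place of cyclopropyl on a nitrogen on an aromatic ring. The whole record in this assay comes down to the limit of > 100000 nM in this assay, at which 2 of the 2 values shown sit. Among the compounds with values here, neither compound has therefore given a readable number, and no measured step has a size to carry over.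

The expected step of a number no higher from compound 2 to compound 3 (the limit leaves the size open) is none beyond the scatter, with no direction foreseen, and another limit is the likeliest report. Compound 3 is estimated at 100000 nM, with an expected range of 30000 nM to 200000 nM.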

Compound 3, half-maximal inhibitory concentration: 27000 nM
For compound 3 the middle estimate is 3.7-fold (0.57 log units) above the measured one; the measured number lies below the stated range.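

In this assay, for the compounds shown here, compound 3 is the first compound here to give a readable number, which shows that a change on this aromatic carbon can bring the read-out off the limit that still holds the other two compounds: the limit of > 100000 nM in this assay, at which 2 of the 3 values shown sit. Allyl(methyl)amino in place of propargylamino gives an at least 3.7-fold lower number from compound 2 to compound 3 (0.56 log units; beyond the scatter) and in place of cyclopropylamino gives an at least 3.7-fold lower number from compound 1 to compound 3 (0.56 log units; beyond the scatter) and both sizes are minimums set by the limits, since the true distance from either limited compound could be larger. Against propargylamino, the entering group has 0 hydrogen-bond donors and a double bond where propargylamino has a triple bond, but a single step cannot tell which of these differences goes with the lower number.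

The step from compound 1 to compound 2 cannot be read, so cyclopropylamino and propargylamino remain unordered in this assay. Going by these compounds, it also remains open whether the methyl or the allyl part of the new group goes with the lower number, and how a dimethylamino group, an allylamino group or a longer chain such as butylamino would read on this carbon.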